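Isoflavone acid chain length versus aldehyde dehydrogenase inhibition

The source may hold more compounds than are shown below. What is called first, only, known or untested is meant among the compounds shown, and "the series" means these compounds.

Measured so far:
compound 1, `CC(Oc1ccc2c(=O)c(-c3ccc(O)cc3)coc2c1)C(=O)O`, 2500 nM
compound 2, `O=C(O)CCCCCOc1ccc2c(=O)cc(-c3ccc(O)cc3)oc2c1`, 3500 nM
compound 3, `CCCCCCC(Oc1ccc2c(=O)c(-c3ccc(O)cc3)coc2c1)C(=O)O`, 2000 nM

In an assay (Cricetulus griseus) for inhibition of aldehyde dehydrogenase, mitochondrial (Homo sapiens) (on this read-out higher numbers stand for weaker inhibition and lower numbers for stronger inhibition), compound 1 gives the second highest of the three numbers. Its nearest neighbour is compound 3, which gives 2000 nM; the step of a 1.3-fold lower number from compound 1 to compound 3 (0.10 log units; within the scatter) is within the scatter, so the two read as equivalent. For the measured compounds named here, compound 2, with a differently arranged core, gives 3500 nM, also within the scatter of compound 1, and no single-point step to it is available.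

The unmeasured compound 4, `O=C(O)CCCCCCOc1ccc2c(=O)c(-c3ccc(O)cc3)coc2c1`, differs from compound 1 in the acid-bearing chain only: 6-carboxyhexyl in place of 1-carboxyethyl on an oxygen on an aromatic ring. Going by the values given here, the only measured step that bears on this chain is the one from compound 1 to compound 3, which added carbon to the same position and produced no change beyond the scatter. Lengthening the chain to the 6-carboxyhexyl and removing the branch is a larger change than that, yet nothing measured here points in either direction, and the three measured values all sit within scatter of one another.

The expectation for compound 4 in this assay is therefore a number near that of compound 1, a 1.1-fold higher number from compound 1 to compound 4 (0.05 log units; within the scatter), with no step beyond the scatter. Compound 4 is estimated at 2800 nM, in the range 1200 nM to 6500 nM.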

Compound 4, half-maximal inhibitory concentration: 50 nM
Compound 4: the middle estimate sits 56-fold (1.75 log units) above what was measured; measured number below the stated range.
By their numbers in this assay, from the lowest: compound 4; then compounds 3, 1 and 2 (each within the scatter of the next).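

In this assay, 6-carboxyhexyl in place of 1-carboxyethyl on an oxygen on an aromatic ring gives a 50-fold lower number from compound 1 to compound 4 (1.70 log units; beyond the scatter), so the acid-bearing chain at this position can move the number far more than the earlier step of a 1.3-fold lower number from compound 1 to compound 3 (0.10 log units; within the scatter) indicated. Added carbon alone does not track with the result in the compounds shown: compound 3, which carries pentyl on the saturated chain carbon of the 1-carboxyethyl group, gives 2000 nM, while the unbranched 6-carboxyhexyl of compound 4 gives 50 nM. No measurement offered here accounts for the gain in this series.

Compound 4 changes chain length and removes the branch in a single step, which leaves open whether either change alone would give the same result, and unbranched chains of intermediate length, such as 3-carboxypropyl, or a longer chain such as 8-carboxyoctyl would be needed to separate the two. Also open, from the compounds shown here alone, is whether the carboxylic acid itself is required at the end of the chain, which an amide or a nitrile in its place on the 6-carbon-type chain of compound 4 would test.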